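Cyclic sulfamide replaces fluorophenylsulfonamide on a shared core

The source may hold more compounds than are shown below. What is called first, only, known or untested is meant among the compounds shown, and "the series" means these compounds.

The series shares one core carrying a chain that ends in a sulfonyl-bearing group, and was examined in a functional assay on cells (Panel melanoma (Carcinoma cell lines), Homo sapiens) for inhibition, read by sulforhodamine B assay, with a stated time of 48 h, tested at 10 uM; on this read-out lower numbers stand for less inhibition and higher numbers for more inhibition at the one concentration tested (going by the name of the read-out). Compound 1 `CN1CCCN(CCNc2nccc(-c3c(-c4cccc(O)c4)nc4sccn34)n2)S1(=O)=O` gives 84.8% in this assay. Compound 2 `O=S(=O)(NCCCNc1nccc(-c2c(-c3cccc(O)c3)nc3sccn23)n1)c1cccc(F)c1` gives 101%, and compound 3 `O=S(=O)(NCCNc1nccc(-c2c(-c3cccc(O)c3)nc3sccn23)n1)c1ccc(F)cc1` gives 75.5%. Among the three numbers compound 3 is the lowest; one gap is a number 9.3 percentage points lower from compound 1 to compound 3 (within the scatter), while the other is a number 25.5 percentage points lower from compound 2 to compound 3 (beyond the scatter). The move between the two open-chain sulfonamides is a number 16.2 percentage points higher from compound 1 to compound 2 (beyond the scatter).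

Compound 4 `CC1(C)CN(CCNc2nccc(-c3c(-c4cccc(O)c4)nc4sccn34)n2)S(=O)(=O)N1` has not yet been measured. Its change from compound 3 is a group of 9 heavy atoms (4 carbon, 2 nitrogen, 2 oxygen, 1 sulfur; one five-membered non-aromatic ring with 3 hetero atoms) in place of a group of 11 heavy atoms (6 carbon, 1 nitrogen, 2 oxygen, 1 fluorine, 1 sulfur; one six-membered aromatic ring of carbon only), on a saturated chain carbon, two bonds along the chain from a nitrogen on an aromatic ring. For the measured compounds named here, the step that bears most directly on it is the one from compound 1 to compound 3, because compound 1 also carries a ring-closed sulfamide on the same chain position and the difference was a number 9.3 percentage points lower from compound 1 to compound 3 (within the scatter), within the scatter. Reversing that kind of change is therefore expected to give a small rise at most, with a number 8.5 percentage points higher from compound 3 to compound 4 (within the scatter). Compound 4 is accordingly estimated to reach 84%, with a range from 68% to 100%.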

Compound 4, a percentage reported as inhibition, at one concentration (the size of the read-out at that concentration, not a potency): 79.7%
Compound 4: middle estimate off by 4.3 percentage points, on the high side; the range from low to high includes it.
By their numbers in this assay, from the lowest: compounds 3, 4 and 1 (each within the scatter of the next); then compound 2.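

In this assay, a group with one five-membered non-aromatic ring with 3 hetero atoms, on a saturated chain carbon, two bonds along the chain from a nitrogen on an aromatic ring, does not separate from the ((4-fluorophenyl)sulfonyl)amino group, with a number 4.2 percentage points higher from compound 3 to compound 4 (within the scatter) and no more than that. It also does not separate from the six-membered ring group of compound 1, with a number 5.1 percentage points lower from compound 1 to compound 4 (within the scatter), so ring size makes no readable difference between these two groups at this position. Only the (((3-fluorophenyl)sulfonyl)amino)methyl group of compound 2 stands apart, with a number 21.3 percentage points lower from compound 2 to compound 4 (beyond the scatter), and nothing shown here accounts for the gap or for the likeness of the other three.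

The compounds shown leave open whether that gap belongs to the extra methyl unit in the chain or to the placing of the fluorine, as the two come together in compound 2. They also leave open how a simple amine or a carboxylic acid would read at this chain end, in place of a group that carries a sulfonyl.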